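The source may hold more compounds than are shown below. What is called first, only, known or untested is meant among the compounds shown, and "the series" means these compounds.

Values in an ADME assay on HeLa cells (Homo sapiens) for cytotoxicity, read by MTT assay; on this read-out higher numbers stand for weaker inhibition and lower numbers for stronger inhibition:
- compound 1 `COc1ccc(C[C@H]2COC(=O)[C@@H]2Cc2ccc(OCc3cn(-c4ccc(F)cc4)nn3)c(OC)c2)cc1OC`: >= 600000 nM (a limit, not a number)
- compound 2 `COc1ccc(C[C@H]2COC(=O)[C@@H]2Cc2ccc(OC(=O)CCC(=O)N3CCCCC3)c(OC)c2)cc1OC`: 128000 nM
- compound 3 `COc1ccc(C[C@H]2COC(=O)[C@@H]2Cc2ccc(OCc3cn(Cc4ccccc4)nn3)c(OC)c2)cc1OC`: 346000 nM

Two of these values are numbers: compound 2 gives 128000 nM and compound 3 gives 346000 nM. The number for compound 3 is the higher of the two, a gap beyond the usual scatter.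

Compound 4 `COc1ccc(C[C@H]2COC(=O)[C@@H]2Cc2ccc(OCC(=O)N3CCOCC3)c(OC)c2)cc1OC` remains unmeasured. It has (morpholin-4-yl)carbonyl in place of 1-benzyl-1H-1,2,3-triazol-4-yl on a saturated chain carbon bound to an oxygen on an aromatic ring.

For the measured compounds named here, no measured step covers this exchange. The only one, an at least 1.7-fold lower number from compound 1 to compound 3 (0.23 log units; that floor lies within the scatter), rests on a limit and concerns the group on the aromatic nitrogen, which compound 4 no longer carries. It therefore gives no size for this change. The nearest guide is compound 2, which also has a carbonyl group in its chain rather than a triazole and gives 128000 nM. This suggests a lean towards a lower number in this assay, but no firm step beyond the scatter is expected.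

The expected change is a 1.6-fold lower number from compound 3 to compound 4 (0.22 log units; within the scatter). Compound 4 is estimated at 210000 nM, with an expected range of 80000 nM to 500000 nM.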

Compound 4, half-maximal inhibitory concentration: >= 600000 nM
Compound 4 gave a limit, no number (the forecaster's own chance of this, stated with the estimate: 15%); middle value at least 2.8-fold (0.45 log units) away from the limit.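

In this assay compound 4 gives >= 600000 nM, which is a limit and not a number. At this position, the exchange of 1-benzyl-1H-1,2,3-triazol-4-yl for (morpholin-4-yl)carbonyl on a saturated chain carbon bound to an oxygen on an aromatic ring gives an at least 1.7-fold higher number from compound 3 to compound 4 (0.23 log units; that floor lies within the scatter), so its direction is indicated but no size beyond the scatter is established. The clearer new finding is an at least 4.6-fold higher number from compound 2 to compound 4 (0.67 log units; beyond the scatter), which shows that a carbonyl-bearing group on this oxygen does not by itself go with the lower number in this assay, as compound 4 and compound 2 both carry one.

The step between compound 1 and compound 4 cannot be read: the limit of >= 600000 nM in this assay, at which 2 of the 4 values shown sit.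

On these data alone, how far compound 4 lies past its limit stays open, so the exchange has a floor but no size. Also open, as far as these compounds go, is how this assay responds to an amine or a carboxylic acid on the same saturated chain carbon, or to a longer chain carrying the (morpholin-4-yl)carbonyl.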